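Dropping One Fluorine from a Lipase Inhibitor

The compounds below may be only part of what the source reports. "The series", "measured", "known", "first", "only" and "open" are said of these compounds alone.

Compound 1, `Cc1c(-c2ccc(F)cc2)cc(C(=O)NC2CCCCCC2)c(=O)n1Cc1ccc(F)cc1`, gives 600 nM in an assay on HEK293 cells for inhibition of Lysophosphatidylserine lipase ABHD12 (Homo sapiens), read by scintillation counting, with stated times of 30 min and 5 min; on this read-out lower numbers stand for stronger inhibition and higher numbers for weaker inhibition.
Compound 2, `Cc1nc(OCc2ccc(F)cc2)c(C(=O)NC2CCCCCC2)cc1-c1ccc(F)cc1`, reaches only the assay limit of > 10000 nM in this assay.
Compound 3, `CC(=O)N[C@@H]1[C@@H](O)[C@H](O)[C@@H](CO)O[C@H]1NC(=O)c1cc(Br)c(C)n(Cc2ccc(F)cc2)c1=O`, likewise reaches only the assay limit of > 10000 nM in this assay.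

Among the measured compounds shown here, compound 1 therefore holds the only measured number; the other two sit at the limit of > 10000 nM in this assay, at which 2 of the 3 values shown sit. Compound 4, `Cc1c(-c2ccccc2)cc(C(=O)NC2CCCCCC2)c(=O)n1Cc1ccc(F)cc1`, differs from compound 1 by hydrogen in place of fluoro on an aromatic carbon, which read one bond further out is 4-fluorophenyl to phenyl. For the measured compounds named here, no measured pair shows this change, so there is no comparison to lean on. The expected step is a 1.3-fold higher number from compound 1 to compound 4 (0.12 log units; within the scatter), small and, if anything, slightly toward weaker inhibition. Compound 4 is thus estimated to give about 800 nM in this assay, within 300 nM to 2500 nM.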

Compound 4, half-maximal inhibitory concentration: > 10000 nM
Compound 4: no number, only a limit (the forecaster's own chance of this, stated with the estimate: 10%); at least 12-fold (1.09 log units) between middle value and limit.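

Hydrogen in place of fluoro on this aromatic carbon, para to a large group, gives an at least 16-fold higher number from compound 1 to compound 4 (1.22 log units; beyond the scatter) in this assay, the first one-place comparison in this series. For compound 4 that reading is a limit and not a number. A single fluoro therefore separates the only compound with a measured number from those at the limit: the limit of > 10000 nM in this assay, at which 3 of the 4 values shown sit.

On these data alone, whether chloro, methyl or methoxy at this place would keep the inhibition seen with compound 1 remains open. So does whether the other fluoro of compound 1 matters as much.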